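Moving the methoxy group: compound 2 to compound 3

The compounds below may be only part of what the source reports. "The series", "measured", "known", "first", "only" and "open" are said of these compounds alone.

- compound 1 `CCN1CCN(c2ccc(S(=O)(=O)Oc3ccc(OC)cc3)cc2)C1=O` gives 60000 nM
- compound 2 `CCCN1CCN(c2ccc(S(=O)(=O)Oc3cccc(OC)c3)cc2)C1=O` gives 25000 nM

Among the measured compounds shown here, both numbers come from a functional assay on HT-29 cells (Homo sapiens) for antiproliferative activity, read by sulforhodamine B assay, with a stated time of 48 h (on this read-out lower numbers stand for stronger inhibition and higher numbers for weaker inhibition), and only two measurements exist so far. Compound 2 has the lower number, 25000 nM on this scale, and compound 1 lies above it by more than the usual scatter of repeated measurements.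

The next compound to be tested is compound 3 `CCCN1CCN(c2ccc(S(=O)(=O)Oc3ccc(OC)cc3)cc2)C1=O`, which has the same atoms as compound 2 joined differently. The change is 4-methoxyphenyl in place of 3-methoxyphenyl on an oxygen and it puts 4-methoxyphenyl in place of 3-methoxyphenyl on an oxygen whose other neighbour is the sulfonyl sulfur.

For the measured compounds named here, no two measured compounds differ in one place only, so this swap has no direct precedent. Going by the values given here, the sole guide is compound 1 at 60000 nM in the same assay, which also carries 4-methoxyphenyl but is not otherwise identical. A small rise in this assay is therefore expected, close to the scatter. The estimated step of a 1.4-fold higher number from compound 2 to compound 3 (0.15 log units; within the scatter) is modest and uncertain. Compound 3 is expected at 35000 nM within an estimated range of 13000 nM to 80000 nM for now.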

Compound 3, half-maximal inhibitory concentration: 16000 nM
Compound 3: the middle estimate sits 2.2-fold (0.34 log units) above what was measured; the range from low to high includes it.
By their numbers in this assay, from the lowest: compounds 3 and 2 (each within the scatter of the next); then compound 1.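

With the methoxy group moved, the swap of 3-methoxyphenyl for 4-methoxyphenyl on the oxygen bonded to the sulfonyl sulfur gives a 1.6-fold lower number from compound 2 to compound 3 (0.19 log units; within the scatter) in this assay, so this assay does not separate these two placements of the methoxy group at this stage. Among the compounds shown here, compound 3 also provides the first comparison of chain length with 4-methoxyphenyl held constant: methyl in place of hydrogen on a saturated chain carbon, two bonds along the chain from an amide-type nitrogen in a ring, gives a 3.8-fold lower number from compound 1 to compound 3 (0.57 log units; beyond the scatter), a modest change but one that, unlike the methoxy move, stands clear of the scatter. Nothing in the available data explains either result.

Going by these compounds, the chain comparison rests on one pair of compounds, so it remains open whether a longer chain such as butyl would continue the same trend or whether the trend would hold with 3-methoxyphenyl in place. On these data alone, the effect of replacing the methoxy group on the ring with another group, such as an amine or a carboxylic acid, also remains open.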